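Dropping the 3-Methoxyphenyl Group from Two Related Cores

The compounds below may be only part of what the source reports. "The series", "measured", "known", "first", "only" and "open" are said of these compounds alone.

Compound 1 `O=C1COc2ccc(-c3cccc(NS(=O)(=O)c4ccc(F)cc4)c3)cc2N1` gives 32100 nM in a functional assay on A549 cells (Homo sapiens) for antiproliferative activity, read by MTT assay, with a stated time of 72 h; a lower number here means a stronger inhibitor, a higher number a weaker inhibitor. Compound 2 `COc1cccc(N2C(=O)COc3ccc(-c4cccc(NS(=O)(=O)c5ccc(F)cc5)c4)cc32)c1` reaches only the limit of this assay, reported as > 40000 nM. Compound 3 `COc1cccc(N2C(=O)COc3ccc(-c4ccc(O)cc4)cc32)c1` also reaches only a limit in this assay, reported as > 40000 nM.

Compound 2 and compound 1 share one core and differ in a single place: hydrogen in place of 3-methoxyphenyl on an amide-type nitrogen in a ring. The step made is an at least 1.2-fold lower number from compound 2 to compound 1 (0.09 log units; that floor lies within the scatter). Since compound 2 stands at the limit of > 40000 nM in this assay, at which 2 of the 3 values shown sit, only a floor can be given for that step, and the floor itself lies within the usual scatter, so the effect of the change on this core cannot be called large or small on the present data.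

Compound 3 carries a different core; the difference between the two cores is not broken down here. Compound 4 `O=C1COc2ccc(-c3ccc(O)cc3)cc2N1` has not yet been measured in this assay. It stands to compound 3 exactly as compound 1 stands to compound 2, the same change at the same place: hydrogen in place of 3-methoxyphenyl on an amide-type nitrogen in a ring.

Compound 4 is expected to give about 40000 nM, with a range from 15000 nM to 120000 nM. Within the data shown here, the step this estimate means is a number no higher from compound 3 to compound 4 (the limit leaves the size open), set beside an at least 1.2-fold lower number from compound 2 to compound 1 (0.09 log units; that floor lies within the scatter) as the only measured example of the change. The expectation is weak because compound 3 sits at the limit of > 40000 nM in this assay, at which 2 of the 3 values shown sit, which gives no number to start from; a limit for compound 4 as well would not be surprising.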

Compound 4, half-maximal inhibitory concentration: > 40000 nM
Compound 4 ended at the assay's limit; the forecaster's own chance of this, stated with the estimate: 60%; the middle value sits exactly at the limit.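

In this assay compound 4 gives > 40000 nM, a limit of the assay and not a number. Compound 3 gives > 40000 nM, also a limit. No step can be read from compound 3 to compound 4, as both stand at a limit: the limit of > 40000 nM in this assay, at which 3 of the 4 values shown sit.

The compounds shown leave open whether hydrogen in place of 3-methoxyphenyl on an amide-type nitrogen in a ring changes the number on either core by more than the usual scatter.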